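Benzyl substituent change on the shared diamino core

The source may report more compounds than this note shows. Statements on the series, on what has been measured and on what is new or still open speak of the compounds shown alone.

Among the measured compounds shown here, the two measured members are compound 1 `COc1ccc(CNc2nc3cc(N)cc(N)c3nc2-c2ccccc2)cc1OC` and compound 2 `Nc1cc(N)c2nc(-c3ccccc3)c(NCc3ccc(F)cc3)nc2c1`. In a functional assay on K562 cells (Homo sapiens) for inhibition, read by sulforhodamine B assay, with a stated time of 48 h (on this read-out higher numbers stand for weaker inhibition of growth and lower numbers for stronger inhibition of growth), compound 1 gives < 100000 nM, which is a limit of the assay and not a number. In this assay compound 2 likewise gives only a limit, < 100000 nM. The step that the two limits leave unreadable from compound 1 to compound 2 therefore cannot be read in size, and compound 2 stands at the limit of < 100000 nM in this assay, at which 2 of the 2 values shown sit, rather than at a number of its own.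

Compound 3 `COc1ccc(CNc2nc3cc(N)cc(N)c3nc2-c2ccccc2)cc1` is the next member to be measured in this assay. It differs from compound 2 in one place: methoxy in place of fluoro on an aromatic carbon. For the measured compounds named here, only one measured step exists, and it is unreadable, both of its ends sitting at the limit of < 100000 nM in this assay, at which 2 of the 2 values shown sit; no measured step therefore bears on the exchange of fluoro for methoxy, and no direction can be taken from the data. Compound 3 is expected, on this basis, to give a value that again lies at or near the limit, with the expected step being a step that the limit leaves unreadable from compound 2 to compound 3. The estimate for compound 3 in this assay is 30000 nM, with a range from 3000 nM to 100000 nM.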

Compound 3, concentration for total growth inhibition: 97700 nM
Beside the measured number, compound 3's estimate is 3.3-fold (0.51 log units) below it; the measured number falls inside the stated range.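

No new step can be read in this assay: compound 1 and compound 2 give no number to set against compound 3, so the steps among all three remain unreadable, for this reason: the limit of < 100000 nM in this assay, at which 2 of the 3 values shown sit.

The compounds shown leave open whether the benzyl substituents of compound 1, compound 2 and compound 3 differ at all in this assay.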